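The source may hold more compounds than are shown below. What is called first, only, known or untested is meant among the compounds shown, and "the series" means these compounds.

Measured in a functional assay on NCI-H1299 cells (Homo sapiens) for antiproliferative activity, with a stated time of 72 h; a lower number here means that less compound is needed, a higher number that more compound is needed for the effect:
compound 1 `CN1CCN(c2ccc(Nc3ncc4c(=O)c(-c5c(Cl)cccc5Cl)cn(C)c4n3)cc2)CC1` gives 520 nM
compound 2 `CN1CCN(c2ccc(Nc3ncc4c(=O)c(-c5c(Cl)cccc5Cl)cn(C5CC5)c4n3)cc2)CC1` gives 460 nM
compound 3 `CN(C)CCn1cc(-c2c(Cl)cccc2Cl)c(=O)c2cnc(Nc3ccc(N4CCN(C)CC4)cc3)nc21` gives 7650 nM

Compound 3 stands with the highest number of the three in this assay; the nearest is compound 1 and the furthest compound 2, both separated from it by steps well beyond the scatter. The step under consideration runs from compound 3 to compound 4 `CN1CCN(c2ccc(Nc3ncc4c(=O)c(-c5c(Cl)cccc5Cl)cn(CC(C)(C)O)c4n3)cc2)CC1`, not yet measured: 1-hydroxy-1-methylethyl in place of (dimethylamino)methyl on a saturated chain carbon bound to an aromatic nitrogen. Among the measured compounds shown here, no measured step exchanges one chain end for another at this place, so the change itself has no direct precedent. What bears on it is what the chain of compound 3 cost: a 15-fold higher number from compound 1 to compound 3 (1.17 log units; beyond the scatter) and a 17-fold higher number from compound 2 to compound 3 (1.22 log units; beyond the scatter), both large, whereas a 1.1-fold lower number from compound 1 to compound 2 (0.05 log units; within the scatter). The high number thus appears only together with the 2-(dimethylamino)ethyl chain, and compound 4 replaces its end while keeping a chain of the same count. Compound 4 is therefore expected to show a lower number, a 5.1-fold lower number from compound 3 to compound 4 (0.71 log units; beyond the scatter), although whether it falls all the way back to the range of compound 1 and compound 2 cannot be told from these three. Compound 4 is estimated at 1500 nM, within 400 nM to 6000 nM.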

Compound 4, half-maximal effective concentration: > 10000 nM
Compound 4: a limit, no number; the forecaster's own chance of this, stated with the estimate: 3%; middle value at least 6.6-fold (0.82 log units) away from the limit.
By their numbers in this assay, from the lowest: compounds 2 and 1 (each within the scatter of the next); then compound 3. At a limit, above all of these: compound 4.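

In this assay compound 4 gives a limit of the assay and not a number: the limit of > 10000 nM in this assay, at which 1 of the 4 values shown sits. Exchanging (dimethylamino)methyl for 1-hydroxy-1-methylethyl on a saturated chain carbon bound to an aromatic nitrogen brings no return towards compound 1 or compound 2, the step being an at least 1.3-fold higher number from compound 3 to compound 4 (0.11 log units; that floor lies within the scatter). Set against the groups with low numbers, the new chain gives an at least 21-fold higher number from compound 2 to compound 4 (1.33 log units; beyond the scatter) and an at least 19-fold higher number from compound 1 to compound 4 (1.28 log units; beyond the scatter), both large, so the high number at this position is no longer tied to the 2-(dimethylamino)ethyl chain alone but appears with both chain ends shown, while methyl and cyclopropyl stay within the scatter of each other.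

The two high-number chains share the same count, which leaves open whether the loss follows the length of the chain or what sits on it, a question that a plain ethyl, a 2-methoxyethyl chain or a carboxylic acid at the chain end would help to separate. On these data alone, how far compound 4 lies beyond compound 3 also stays open, since a limit gives only a floor for that step.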